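The source may hold more compounds than are shown below. What is called first, only, known or untested is meant among the compounds shown, and "the series" means these compounds.

In an ADME assay on HEL cells (Homo sapiens) for cytotoxicity, read by microscopy (on this read-out lower numbers stand for higher toxicity in this test and higher numbers for lower toxicity in this test), compound 1 `Nc1ncc(Br)c2c1ncn2[C@@H]1C[C@H](O)[C@@H](O)[C@H]1O` gives > 200000 nM, which is a limit of the assay and not a number. Compound 2 `Nc1ncc(I)c2c1ncn2[C@@H]1C[C@H](O)[C@@H](O)[C@H]1O` gives > 100000 nM, again only a limit. The step that the two limits leave unreadable from compound 1 to compound 2 is therefore of a size that cannot be read. Compound 3 `Nc1ncc(Cl)c2c1ncn2[C@@H]1C[C@H](O)[C@@H](O)[C@H]1O` differs from compound 2 by chloro in place of iodo on an aromatic carbon. Among the compounds with values here, the only evidence, the limit of > 100000 nM in this assay, at which 1 of the 2 values shown sits, and (the limit of > 200000 nM in this assay, at which 1 of the 2 values shown sits), consists of two limits, so no direction and no size beyond the scatter can be foreseen for this step. The expected step for compound 3 is a step that the limit leaves unreadable from compound 2 to compound 3. Compound 3 is estimated at 200000 nM, between 50000 nM and 1000000 nM, most likely reported again only as a limit.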

Compound 3, minimum cytotoxic concentration: > 100000 nM
Compound 3 ended at the assay's limit (the forecaster's own chance of this, stated with the estimate: 85%); the middle value lies beyond the limit too.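

In this assay, within the data shown here, compound 1, compound 2 and compound 3 all give limits rather than numbers, so no step among them can be read. From the compounds shown here alone, the concentration at which any of them becomes toxic to these cells remains open.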